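This account rests on a few compounds, and the source may have more. Where it says the series, first, only, none or still open, it means among the compounds named here.

Measured in an in vitro ADME assay on microsomes from liver (Homo sapiens) for metabolic stability (a lower number here means slower removal, a higher number faster removal of the compound), each value a limit of the assay:
- Compound 1 `Cc1cc(Nc2ccc(S(F)(F)(F)(F)F)cc2)n2nc(C(F)(F)F)nc2n1`: < 5 mL.min-1.g-1
- Compound 2 `Cc1cc(Nc2ccc(S(F)(F)(F)(F)F)cc2)n2nc(C3CC3)nc2n1`: < 5 mL.min-1.g-1
- Compound 3 `CCC(F)(F)c1nc2nc(C)cc(Nc3ccc(S(F)(F)(F)(F)F)cc3)n2n1`: < 5 mL.min-1.g-1

Compound 3 gives only a limit, < 5 mL.min-1.g-1. It shares that position with the other two compounds: the limit of < 5 mL.min-1.g-1 in this assay, at which 3 of the 3 values shown sit. Compound 4 `CCOc1nc2nc(C)cc(Nc3ccc(S(F)(F)(F)(F)F)cc3)n2n1` differs from it by one change: ethoxy in place of 1,1-difluoropropyl on an aromatic carbon. Three measured steps change the same group: a step that the two limits leave unreadable from compound 1 to compound 2, a step that the two limits leave unreadable from compound 1 to compound 3 and a step that the two limits leave unreadable from compound 2 to compound 3. None has a readable size, and none brings in ethoxy. No step beyond the scatter is therefore expected in this assay, and no direction can be expected from these data. The expected step is a number no lower from compound 3 to compound 4 (the limit leaves the size open). Compound 4 is estimated at 5 mL.min-1.g-1, with an expected range from 3 mL.min-1.g-1 to 14 mL.min-1.g-1.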

Compound 4, intrinsic clearance in microsomes: < 5 mL.min-1.g-1
Compound 4: only a limit was reported; the forecaster's own chance of this, stated with the estimate: 55%; the middle value sits exactly at the limit.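

Compound 4 gives only a limit, so no step to it from compound 1, compound 2 or compound 3 can be read in this assay: the limit of < 5 mL.min-1.g-1 in this assay, at which 4 of the 4 values shown sit.

The compounds shown leave open whether ethoxy, trifluoromethyl, cyclopropyl and 1,1-difluoropropyl differ at all in this assay.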